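Cytotoxicity notes on the series, compound 3 to compound 4

This account rests on a few compounds, and the source may have more. Where it says the series, first, only, none or still open, it means among the compounds named here.

Compound 1 `CCOc1ccc(C(=O)Nc2cc3nc(C4CCCCC4)[nH]c3cc2N(CC)CC)cc1`, compound 2 `CCN(CC)c1cc2[nH]c(C3CCCCC3)nc2cc1NC(=O)c1ccc(C)cc1` and compound 3 `CN(C)c1cc2[nH]c(C3CCCCC3)nc2cc1NC(=O)c1cccc(Br)c1` share one core and differ in the aryl amide and in the amine. In an ADME assay on Vero cells (Chlorocebus sabaeus) for cytotoxicity, read by resazurin assay, with a stated time of 3 days (on this read-out higher numbers stand for weaker inhibition and lower numbers for stronger inhibition), compound 1 gives > 100 ug/mL, a limit of the assay and not a number. Compound 2 gives > 100 ug/mL, also a limit. Compound 3 gives > 100 ug/mL, again a limit. The step that the two limits leave unreadable from compound 1 to compound 2 is unreadable because the limit of > 100 ug/mL in this assay, at which 3 of the 3 values shown sit, holds every value shown. Compound 4 `CCN(CC)c1cc2[nH]c(C3CCCCC3)nc2cc1NC(=O)c1cccc(Br)c1` is not yet measured; it differs from compound 3 by diethylamino in place of dimethylamino on an aromatic carbon. Among the compounds with values here, no measured step bears on this change, and compound 3 itself stands only at a limit. Compound 4 is expected to stay near the limit, estimated at 150 ug/mL, range 70 ug/mL to 400 ug/mL, meaning an expected step that the limit leaves unreadable from compound 3 to compound 4 of no size beyond the scatter.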

Compound 4, half-maximal inhibitory concentration: > 100 ug/mL
Compound 4: only a limit was reported; the forecaster's own chance of this, stated with the estimate: 85%; the middle value lies beyond the limit too.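

Within the data shown here, no step from compound 1, compound 2 or compound 3 to compound 4 can be read in this assay, because all four compounds stand at a limit and not a number: the limit of > 100 ug/mL in this assay, at which 4 of the 4 values shown sit. The compounds shown leave open whether any change of aryl amide or amine on the shared core shifts cytotoxicity.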